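Removing the Ester Methyl: From Compound 1 to Compound 4

This account rests on a few compounds, and the source may have more. Where it says the series, first, only, none or still open, it means among the compounds named here.

Three measured compounds share one core and differ only in the chain on the ester oxygen. Compound 1 `COC(=O)c1ccc(COC(COCc2ccc(OC)cc2)Cn2ccnc2)cc1` gives 1260 nM in a functional assay for inhibition of Thromboxane-A synthase (Homo sapiens) (on this read-out lower numbers stand for stronger inhibition and higher numbers for weaker inhibition), and stands second highest of the three numbers. Compound 2 `CCCOC(=O)c1ccc(COC(COCc2ccc(OC)cc2)Cn2ccnc2)cc1` gives 180 nM, while compound 3 `CCCCCCCCOC(=O)c1ccc(COC(COCc2ccc(OC)cc2)Cn2ccnc2)cc1` gives 21000 nM. Lengthening the ester chain gives a 7.0-fold lower number from compound 1 to compound 2 (0.85 log units; beyond the scatter), but a 17-fold higher number from compound 1 to compound 3 (1.22 log units; beyond the scatter) and a 120-fold higher number from compound 2 to compound 3 (2.07 log units; beyond the scatter). Compound 4 `COc1ccc(COCC(Cn2ccnc2)OCc2ccc(C(=O)O)cc2)cc1` differs from compound 1 by hydrogen in place of methyl on an oxygen next to a carbonyl group. For the measured compounds named here, no measured step removes the chain entirely, and the steps that alter it point in both directions, so only a modest step is expected, with uncertain direction. Compound 4 is therefore estimated at 2500 nM, within 500 nM to 15000 nM, an expected step of a 2.0-fold higher number from compound 1 to compound 4 (0.30 log units; within the scatter).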

Compound 4, half-maximal inhibitory concentration: 6700 nM
Estimate against measurement, compound 4: 2.7-fold (0.43 log units) below; measured number inside the range.
By their numbers in this assay, from the lowest: compound 2; then compound 1; then compound 4; then compound 3.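

Replacing the ester chain with hydrogen gives the free carboxy group, and this change can now be read against all three esters: a 5.3-fold higher number from compound 1 to compound 4 (0.73 log units; beyond the scatter), a 37-fold higher number from compound 2 to compound 4 (1.57 log units; beyond the scatter), yet a 3.1-fold lower number from compound 3 to compound 4 (0.50 log units; beyond the scatter). Hydrogen at this oxygen therefore falls between methyl and octyl, while compound 2, with its propyl chain, keeps the lowest number of the four. Nothing available explains these differences.

The compounds shown leave open how a butyl or pentyl ester would read, and so where along the chain the numbers turn upward. On these data alone, an amide in place of the ester remains equally open.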